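Removing the Methyl: Difluorophenyl Returns to the Triazole

This account rests on a few compounds, and the source may have more. Where it says the series, first, only, none or still open, it means among the compounds named here.

Compound 3 `COc1cc2c(Oc3ccc(NC(=O)c4cn(-c5ccccc5C)nn4)cc3F)ccnc2cc1OCCCN1CCN(C)CC1` stands highest of the three measured numbers in a functional assay on NCI-H460 cells (Homo sapiens) for cytotoxicity, read by MTT assay, with a stated time of 72 h (a higher number here means a weaker inhibitor, a lower number a stronger inhibitor), with 3650 nM. The change to compound 4 `COc1cc2c(Oc3ccc(NC(=O)c4cn(-c5ccc(F)c(F)c5)nn4)cc3F)ccnc2cc1OCCCN1CCN(C)CC1` is 3,4-difluorophenyl in place of 2-methylphenyl on an aromatic nitrogen. Among the compounds with values here, the one step that bears on it is an 18-fold higher number from compound 2 to compound 3 (1.26 log units; beyond the scatter), where compound 2 `COc1cc2c(Oc3ccc(NC(=O)c4cn(-c5ccccc5)nn4)cc3F)ccnc2cc1OCCCN1CCN(C)CC1` gave 200 nM. Compound 1 `COc1cc2c(Oc3ccc(NC(=O)c4cn(-c5ccc(F)c(F)c5)nn4)cc3F)ccnc2cc1OCCCN1CCCCC1` carries the same 3,4-difluorophenyl that enters in compound 4, though with a different tail; in this assay compound 1 gave 250 nM. Taking the methyl away is expected to undo that large loss, and compound 4 is expected to show a large step down in this assay, a 16-fold lower number from compound 3 to compound 4 (1.20 log units; beyond the scatter). Compound 4 is therefore estimated at 230 nM, within 100 nM to 600 nM.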

Compound 4, half-maximal inhibitory concentration: 250 nM
Beside the measured number, compound 4's estimate is 1.1-fold (0.04 log units) below it; low and high end bracket the measured number.
By their numbers in this assay, from the lowest: compounds 2, 1 and 4 (each within the scatter of the next); then compound 3.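

In this assay, 3,4-difluorophenyl on the aromatic nitrogen stands far from 2-methylphenyl (a 15-fold lower number from compound 3 to compound 4 (1.16 log units; beyond the scatter)), so the high number of compound 3 does not extend to every substituted phenyl at this position. Neither the added fluorines (a 1.3-fold higher number from compound 2 to compound 4 (0.10 log units; within the scatter)) nor the exchange of tail (no change at the digits printed from compound 1 to compound 4 (within the scatter)) moves the number beyond the scatter. No measurement shown here accounts for these results.

The compounds shown leave open whether a chlorine or a methoxy group on the phenyl would bring the same loss as the methyl of compound 3. They also leave open how a morpholine tail would compare.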